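Notes on a steroid 5-alpha-reductase series: compound 3

The source may report more compounds than this note shows. Statements on the series, on what has been measured and on what is new or still open speak of the compounds shown alone.

Measured so far:
compound 1 `CCCCCC(c1ccccc1)n1ccc2cc(/C(C)=C/C(=O)Nc3ccccc3OCCCC(=O)O)ccc21` — 25 nM
compound 2 `C/C(=C\C(=O)Nc1ccccc1OCCCC(=O)O)c1ccc2c(ccn2C(CC(C)C)c2ccccc2)c1` — 6.3 nM

In an assay on Prostate gland for inhibition of steroid 5-alpha-reductase (Rattus norvegicus) (a lower number here means a stronger inhibitor, a higher number a weaker inhibitor), compound 2 gives the lowest of the two numbers; its nearest neighbour is compound 1, separated by the step of a 4.0-fold lower number from compound 1 to compound 2 (0.60 log units; beyond the scatter). Compound 3 `C/C(=C\C(=O)Nc1ccccc1OCCCC(=O)O)c1ccc2c(ccn2C(c2ccccc2)c2ccncc2)c1` differs from compound 2 by pyridin-4-yl in place of isobutyl on a saturated chain carbon bound to an aromatic carbon and an aromatic nitrogen. For the measured compounds named here, the only known step, from compound 1 to compound 2, exchanges one saturated chain for another at the same carbon and so bears on this ring-for-chain exchange only loosely. A modest rise in this assay is therefore expected. For compound 3 the estimate is 15 nM, between 4 nM and 60 nM. This means a step of a 2.4-fold higher number from compound 2 to compound 3 (0.38 log units; beyond the scatter) is expected.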

Compound 3, half-maximal inhibitory concentration: 26 nM
The estimate for compound 3 lay 1.7-fold (0.24 log units) below the measured number, and the stated range covers the measured number.
By their numbers in this assay, from the lowest: compound 2; then compounds 1 and 3 (each within the scatter of the next).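

In this assay, a ring is accepted at this saturated chain carbon, but pyridin-4-yl does not keep the lower number reached with isobutyl (a 4.1-fold higher number from compound 2 to compound 3 (0.62 log units; beyond the scatter)). Against pentyl, the same ring gives no separable change (a 1.0-fold higher number from compound 1 to compound 3 (0.02 log units; within the scatter)). Compounds 1 and 3 therefore cannot be told apart here, despite carrying a chain and a ring. Whether the ring or its nitrogen accounts for the rise from compound 2 remains open; cyclohexyl or pyridin-2-yl at this carbon would bear on that question. No supporting evidence bears on this result.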